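The source may hold more compounds than are shown below. What is called first, only, known or untested is meant among the compounds shown, and "the series" means these compounds.

Working notes on the series, read in a functional assay on RS4-11 cells (Homo sapiens) for inhibition, read by CCK-8 assay, with a stated time of 48 h, tested at 20 uM; a higher number here means more inhibition of growth at the concentration tested, a lower number less inhibition of growth. Compound 1 `COc1ccc(Cc2nnc(NC(=O)/C(C#N)=C/c3ccccc3OS(=O)(=O)c3ccc(C)cc3)s2)cc1` gives 70%, and compound 2 `Cc1ccc(S(=O)(=O)Oc2ccccc2/C=C(\C#N)C(=O)Nc2nnc(Cc3cccc4ccccc34)s2)cc1` gives 73%. Within the data shown here, these two values lie within the scatter of each other, so compound 2 stands level with the only other measured compound and neither can be ranked above the other.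

The next compound is compound 3 `Cc1ccc(S(=O)(=O)Oc2ccccc2/C=C(\C#N)C(=O)Nc2nnc(Cc3ccccc3)s2)cc1`. Its change from compound 2 is phenyl in place of naphthalen-1-yl on a saturated chain carbon bound to an aromatic carbon. Among the measured compounds shown here, one measured step bears on this place, a number 3 percentage points higher from compound 1 to compound 2 (within the scatter), where naphthalen-1-yl replaced 4-methoxyphenyl. For the measured compounds named here, that single step stayed within the scatter, although it is the only evidence and no measured compound yet carries phenyl here. On the strength of a number 3 percentage points higher from compound 1 to compound 2 (within the scatter), no step beyond the scatter is expected in this assay, and no direction can be firmly assigned. The estimated change is small: a number 5 percentage points lower from compound 2 to compound 3 (within the scatter). The expected value for compound 3 is 68%, with an estimated range of 52% to 82%.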

Compound 3, percent growth inhibition at one concentration: 69%
Beside the measured number, compound 3's estimate is 1 percentage points below it; low and high end bracket the measured number.
By their numbers in this assay, from the lowest: compounds 3, 1 and 2 (each within the scatter of the next).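

In this assay the step that takes out the second aromatic ring, phenyl in place of naphthalen-1-yl on a saturated chain carbon bound to an aromatic carbon, gives a number 4 percentage points lower from compound 2 to compound 3 (within the scatter) and the step with hydrogen in place of methoxy on an aromatic carbon gives a number 1 percentage points lower from compound 1 to compound 3 (within the scatter) so neither change separates the compounds. This place now carries three aryl groups, 4-methoxyphenyl, naphthalen-1-yl and phenyl, and all three compounds stand level, so for these compounds neither the methoxy group nor the second ring of naphthalen-1-yl is needed to hold the growth inhibition seen at this one concentration. Nothing measured alongside these values offers an explanation for this level result.

On these data alone, all three compounds carry an aromatic ring at this place, so the effect of an amine, a carboxylic acid or a longer alkyl chain on that saturated chain carbon stays open. A single-concentration percentage also leaves open whether compounds 1, 2 and 3 would remain level across a full concentration range.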